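The compounds below may be only part of what the source reports. "The series", "measured", "known", "first", "only" and "open" are said of these compounds alone.

Compound 3 `Cc1cc(S(=O)(=O)/N=C(\N)n2nccc2-c2ccccc2)c(SCc2cccc3ccccc23)cc1Cl` gives 11000 nM in an ADME assay on HaCaT cells (Homo sapiens) for cytotoxicity, read by MTT assay, with a stated time of 72 h (a higher number here means a weaker inhibitor, a lower number a stronger inhibitor), the lowest of the three numbers recorded; compound 1 `Cc1cc(-c2ccccc2)n(/C(N)=N/S(=O)(=O)c2cc(C)c(Cl)cc2SCc2cccc3ccccc23)n1` gives 12000 nM and sits within the scatter of it, while compound 2 `Cc1ccc(CSc2cc(Cl)c(C)cc2S(=O)(=O)/N=C(\N)n2nc(C)cc2-c2ccccc2)cc1` gives 30000 nM. Compound 4 `Cc1cc(S(=O)(=O)/N=C(\N)n2nccc2-c2ccccc2)c(SCc2ccccc2Cl)cc1Cl` differs from compound 3 by 2-chlorophenyl in place of naphthalen-1-yl on a saturated chain carbon bound to a sulfur. Among the compounds with values here, the only measured step at the same place, a 2.5-fold higher number from compound 1 to compound 2 (0.40 log units; beyond the scatter), exchanged the same naphthalen-1-yl for a one-ring aryl group and read as a modest rise in this assay. Compound 4 is therefore expected to show a similar modest rise, a 2.0-fold higher number from compound 3 to compound 4 (0.30 log units; within the scatter), and its estimate in this assay is 22000 nM, with a range from 9000 nM to 50000 nM.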

Compound 4, half-maximal inhibitory concentration: 20000 nM
Compound 4: middle estimate off by 1.1-fold (0.04 log units), on the high side, within the range that was stated.
By their numbers in this assay, from the lowest: compounds 3, 1, 4 and 2 (each within the scatter of the next, the first and the last beyond it).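

In this assay, the step of a 1.8-fold higher number from compound 3 to compound 4 (0.26 log units; within the scatter) shows that at this position, on a saturated chain carbon bound to a sulfur, naphthalen-1-yl can give way to the one-ring 2-chlorophenyl with the change staying within the scatter. The earlier exchange for 4-methylphenyl, a 2.5-fold higher number from compound 1 to compound 2 (0.40 log units; beyond the scatter), went beyond it, so a one-ring group does not always stay within the scatter. Nothing available here explains this result. The two exchanges sit on different cores, so the compounds shown cannot separate the aryl group's effect from that of the core. Going by these compounds, how a cyclohexyl group or a carboxylic acid would read at this position stays open.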